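A few compounds are considered here, and "the series" means these few. Any claim that something is new, unique, unknown or untested is made for them only; others in the source may bear on it.

In a functional assay on HT-29 cells (Homo sapiens) for antiproliferative activity, read by sulforhodamine B assay, with a stated time of 48 h (on this read-out lower numbers stand for stronger inhibition and higher numbers for weaker inhibition), three compounds have been measured:

- Compound 1 `O=C1NCCN1c1ccc(S(=O)(=O)Nc2ccc(F)cc2)cc1` gives 370 nM
- Compound 2 `O=C1NCCN1c1ccc(S(=O)(=O)Nc2ccccc2)cc1` gives 280 nM
- Compound 3 `Cc1ccc(C)c(NS(=O)(=O)c2ccc(N3CCNC3=O)cc2)c1` gives 46 nM

Compound 3 stands lowest of the three at 46 nM on this read-out, and its steps from the other two both lie beyond the scatter. Compound 4 `COc1cccc(NS(=O)(=O)c2ccc(N3CCNC3=O)cc2)c1` has not yet been measured. It carries 3-methoxyphenyl in place of 2,5-dimethylphenyl on a sulfonamide nitrogen.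

The most relevant steps are changes at that same nitrogen. Installing 2,5-dimethylphenyl there gave a 6.1-fold lower number from compound 2 to compound 3 (0.78 log units; beyond the scatter) and also an 8.0-fold lower number from compound 1 to compound 3 (0.91 log units; beyond the scatter) in this assay as modest steps. The swap of hydrogen for fluoro gave a 1.3-fold lower number from compound 1 to compound 2 (0.12 log units; within the scatter) and says little here. Going by the values given here, no measured compound carries a methoxy group, so the data offer no direct guide to it.

With 2,5-dimethylphenyl gone, much of the step seen in a 6.1-fold lower number from compound 2 to compound 3 (0.78 log units; beyond the scatter) is expected to be lost. The expected change is a 3.3-fold higher number from compound 3 to compound 4 (0.51 log units; beyond the scatter) in this assay and remains uncertain. For compound 4 the estimated value is 150 nM with an expected range from 45 nM to 500 nM in this assay.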

Compound 4, half-maximal inhibitory concentration: 120 nM
Compound 4: middle estimate off by 1.3-fold (0.10 log units), on the high side; measured number inside the range.
By their numbers in this assay, from the lowest: compound 3; then compound 4; then compounds 2 and 1 (each within the scatter of the next).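

In this assay, going by these compounds alone, 3-methoxyphenyl on the sulfonamide nitrogen gives a 2.3-fold lower number from compound 2 to compound 4 (0.37 log units; beyond the scatter) and a 3.1-fold lower number from compound 1 to compound 4 (0.49 log units; beyond the scatter), so 2,5-dimethylphenyl is not the only group here that gives a clear gain over phenyl and 4-fluorophenyl. The same group still falls short of 2,5-dimethylphenyl, with a 2.6-fold higher number from compound 3 to compound 4 (0.42 log units; beyond the scatter) in this comparison, so the two substituted rings are not interchangeable. This is also the first sign that a ring carrying an oxygen-linked group is tolerated at this nitrogen, and that the number depends on which group the ring carries, as 4-fluorophenyl stays within the scatter of plain phenyl.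

From the compounds shown here alone, whether an amine, a carboxylic acid or a longer ether chain on this ring would approach compound 3 remains open. No supporting evidence is available to explain why these groups differ.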